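Replacing a hydroxyethyl chain with a dioxolane ring

This account rests on a few compounds, and the source may have more. Where it says the series, first, only, none or still open, it means among the compounds named here.

Compound 1 `COc1cccc(Cn2cc(-c3ccc(C(F)(F)F)cc3)nn2)c1`: 17400 nM
Compound 2 `CC1(C)OC[C@H](Cn2cc(-c3ccc([N+](=O)[O-])cc3)nn2)O1`: a limit, > 100000 nM
Compound 3 `OCCCn1cc(-c2ccc(C(F)(F)F)cc2)nn1`: a limit, > 100000 nM

In a functional assay on B16 cells (Mus musculus) for cytotoxicity, read by MTT assay, with a stated time of 48 h (on this read-out lower numbers stand for stronger inhibition and higher numbers for weaker inhibition), compound 1 gives 17400 nM. Compound 2 gives only a limit of the assay, > 100000 nM. Compound 3 likewise gives only a limit, > 100000 nM, so its position is known only as a limit, and one further value among the three shown is a limit as well, namely (the limit of > 100000 nM in this assay, at which 2 of the 3 values shown sit). Within the data shown here, the single measured step that touches compound 3 is an at least 5.7-fold higher number from compound 1 to compound 3 (0.75 log units; beyond the scatter), where 2-hydroxyethyl replaced 3-methoxyphenyl on a saturated chain carbon bound to an aromatic nitrogen.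

Compound 4 `CC1(C)OC[C@H](Cn2cc(-c3ccc(C(F)(F)F)cc3)nn2)O1` is not yet measured. It differs from compound 3 by 2,2-dimethyl-1,3-dioxolan-4-yl in place of 2-hydroxyethyl on a saturated chain carbon bound to an aromatic nitrogen. Compound 2 carries the same 2,2-dimethyl-1,3-dioxolan-4-yl group at the same place but a different substituent on the aryl ring, and compound 2 sits at the limit. Among the measured compounds shown here, the step from compound 1 to compound 3 shows that the 2-hydroxyethyl variant lies well beyond the scatter from the aryl-bearing compound 1, but no measured step shows what the dioxolane ring does on this trifluoromethyl series.

Compound 4 is therefore expected to show an at least 1.2-fold lower number from compound 3 to compound 4 (0.09 log units; that floor lies within the scatter). The estimate for compound 4 is 80000 nM, with a range from 20000 nM to 300000 nM.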

Compound 4, half-maximal inhibitory concentration: > 100000 nM
Compound 4 gave a limit, no number; the forecaster's own chance of this, stated with the estimate: 55%; middle value at least 1.2-fold (0.09 log units) away from the limit.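

At the place on a saturated chain carbon bound to an aromatic nitrogen, this assay gives an at least 5.7-fold higher number from compound 1 to compound 4 (0.75 log units; beyond the scatter), which makes 2,2-dimethyl-1,3-dioxolan-4-yl the second replacement of 3-methoxyphenyl on the trifluoromethyl series to raise the number beyond the scatter, after an at least 5.7-fold higher number from compound 1 to compound 3 (0.75 log units; beyond the scatter). Among the compounds shown, only compound 1, with 3-methoxyphenyl, gives a number rather than a limit, and the other values sit together: the limit of > 100000 nM in this assay, at which 3 of the 4 values shown sit. The steps from compound 3 to compound 4 and from compound 2 to compound 4 cannot be read, as both ends of each are limits, so 2,2-dimethyl-1,3-dioxolan-4-yl cannot be ranked against 2-hydroxyethyl, nor trifluoromethyl against nitro.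

The compounds shown leave open which part of 3-methoxyphenyl goes with the measurable value, and whether an unsubstituted phenyl or a cyclohexyl at this place would also give a number rather than a limit. Also open, as far as these compounds go, is whether an amine or a carboxylic acid on the chain would bring a compound off the limit, and whether nitro in place of trifluoromethyl would change the number of compound 1.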